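Second substituent on the core of compound 2: working notes

The source may hold more compounds than are shown below. What is called first, only, known or untested is meant among the compounds shown, and "the series" means these compounds.

Compound 1 `c1ccc(Oc2ccc(NC3=NCCN3)cc2)cc1` and compound 2 `c1ccc(Sc2ccc(NC3=NCCN3)cc2)cc1` share most of their structure, but the difference between the two cores is not broken down here. In an ADME assay on L6 cells (Rattus norvegicus) for cytotoxicity (a lower number here means a stronger inhibitor, a higher number a weaker inhibitor), compound 1 gives 167000 nM. In the same test compound 2 gives 28500 nM, a number whose gap to that of compound 1 lies beyond the scatter.

Compound 3 `c1cc(Oc2ccc(NC3=NCCN3)cc2)ccc1NC1=NCCN1` carries, relative to compound 1, the change (a group of 6 heavy atoms (3 carbon, 3 nitrogen; one five-membered non-aromatic ring with 2 hetero atoms) in place of a hydrogen atom, on an aromatic carbon). The resulting step of a 4.1-fold lower number from compound 1 to compound 3 (0.61 log units; beyond the scatter) is modest but clear. In this assay compound 3 gives 41000 nM; set against compound 2 this lies within the scatter, so no order between compound 2 and compound 3 is claimed.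

Compound 4 `c1cc(Sc2ccc(NC3=NCCN3)cc2)ccc1NC1=NCCN1` has not yet been measured. It differs from compound 2 by a group of 6 heavy atoms (3 carbon, 3 nitrogen; one five-membered non-aromatic ring with 2 hetero atoms) in place of a hydrogen atom, on an aromatic carbon, the same change that separates compound 3 from compound 1, made on an identically described place; it occurs twice among these four compounds. For the measured compounds named here, only one measured instance of the change exists, on a different core, so the transfer carries real uncertainty.

The step from compound 2 to compound 4 is expected to be about a 3.6-fold lower number from compound 2 to compound 4 (0.55 log units; beyond the scatter), resting on that single earlier instance, a 4.1-fold lower number from compound 1 to compound 3 (0.61 log units; beyond the scatter). In this assay compound 4 is therefore estimated at 8000 nM, with a likely span from 3000 nM to 22000 nM.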

Compound 4, half-maximal inhibitory concentration: 23300 nM
Compound 4: middle estimate off by 2.9-fold (0.46 log units), on the low side, outside the stated range (above it).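

On the core of compound 2, the added group gives a 1.2-fold lower number from compound 2 to compound 4 (0.09 log units; within the scatter) in this assay, so no shift in the number can be claimed for this core, although the same change gave a clear step on the core of compound 1. The size of the step therefore did not carry from one core to the other in this series, and a value for a compound with this group cannot safely be read from a single instance on another core: the same change on two cores in this assay, a 4.1-fold lower number (0.61 log units; beyond the scatter) from compound 1 to compound 3 and a 1.2-fold lower number (0.09 log units; within the scatter) from compound 2 to compound 4, 3.3-fold (0.52 log units) apart, beyond the scatter of two such steps

For the compounds shown here, this rests on only two pairs, so it shows that the step depends on the core in these compounds, but it gives no reason for that dependence and no general rule for the series.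

The compounds shown leave open whether a third core would follow the step seen on compound 1, the near absence of a step seen on compound 2, or neither. They also leave open whether an amine, a carboxylic acid or a longer chain on the same aromatic carbon, para to the large group, would depend on the core in the same way in this assay.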